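A few compounds are considered here, and "the series" means these few. Any claim that something is new, unique, unknown or untested is made for them only; others in the source may bear on it.

Of the compounds shown here, three have so far been measured in an assay on NIH3T3 cells with Urotensin-2 receptor (Homo sapiens) as the target; on this read-out higher numbers stand for an effect only at larger amounts of compound and lower numbers for an effect already at smaller amounts. Compound 2 `Cc1cccc(C(=O)OC(CCN(C)C)c2ccc(Cl)cc2)c1C` gives 1150 nM, and compound 1 `Cc1ccccc1C(=O)OC(CCN(C)C)c1ccc(Cl)cc1` gives 1700 nM. The two differ in one place, (hydrogen in place of methyl on an aromatic carbon). Compound 3 `Cc1cc(C)c(C(=O)NC(CCN(C)C)c2ccc(Cl)cc2)cc1C` gives 1780 nM. How the core of compound 3 differs from that of compound 2 is not broken down here; the values of compound 3 and compound 2 lie within the scatter of each other, as do those of compound 3 and compound 1.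

Compound 4 `Cc1ccc(C(=O)NC(CCN(C)C)c2ccc(Cl)cc2)c(C)c1` has not yet been measured. It differs from compound 3 by hydrogen in place of methyl on an aromatic carbon. Among the compounds with values here, this is the same kind of change as the one between compound 2 and compound 1, though the surroundings are not identical: in compound 3 the aromatic carbon in question is also para to a methyl group, whereas in compound 2 it is only ortho to a methyl group and meta to a large group. The earlier step gave a 1.5-fold higher number from compound 2 to compound 1 (0.17 log units; within the scatter). For compound 4 the step of a 1.1-fold higher number from compound 3 to compound 4 (0.05 log units; within the scatter) is expected to be of similar, small size. Compound 4 is therefore estimated at 2000 nM, with a range from 900 nM to 4500 nM.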

Compound 4, half-maximal effective concentration: 1550 nM
Beside the measured number, compound 4's estimate is 1.3-fold (0.11 log units) above it; the range from low to high includes it.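

In this assay, hydrogen in place of methyl on an aromatic carbon of the core of compound 3 gives a 1.1-fold lower number from compound 3 to compound 4 (0.06 log units; within the scatter). Set beside the earlier step on the other core, the new step cannot be told apart from it: the same change on two cores in this assay, a 1.5-fold higher number (0.17 log units; within the scatter) from compound 2 to compound 1 and a 1.1-fold lower number (0.06 log units; within the scatter) from compound 3 to compound 4, 1.7-fold (0.23 log units) apart, within the scatter of two such steps. This shows that, in these two pairs, the change leaves the number within the scatter on both cores, but it does not show a direction for the change, and two pairs cannot show that the step would stay this small on any further core.

The compounds shown carry only methyl groups or hydrogen on the ring in question, so it remains open what a larger or different group there, such as methoxy, trifluoromethyl or chlorine, would do to the number. Within the data shown here, also open is how the series would respond to a step large enough to stand clear of the scatter, for instance a longer chain in place of the one bearing the dimethylamino group.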